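Acetyl in Place of Cyano: Expected Cytotoxicity for Compound 3

This account rests on a few compounds, and the source may have more. Where it says the series, first, only, none or still open, it means among the compounds named here.

Two compounds sharing one core have been examined. Compound 1 `ClC(Cl)(Cl)c1nc(Oc2ccc(Br)cc2)c2ccccc2n1` carries a bromo group; in an ADME assay on HepG2 cells (Homo sapiens) for cytotoxicity, read by MTT assay, with a stated time of 72 h (on this read-out lower numbers stand for higher toxicity in this test and higher numbers for lower toxicity in this test), compound 1 gives 45000 nM. Compound 2 `N#Cc1ccc(Oc2nc(C(Cl)(Cl)Cl)nc3ccccc23)cc1` carries a cyano group where compound 1 carries bromo. In this assay compound 2 gives only a limit, > 8000 nM. Compound 2 therefore stands at the edge of what was measured, and its exact value is not known. Among the compounds with values here, the one measured step, a step that the limit leaves unreadable from compound 1 to compound 2, cannot be sized, since (the limit of > 8000 nM in this assay, at which 1 of the 2 values shown sits).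

Compound 3 `CC(=O)c1ccc(Oc2nc(C(Cl)(Cl)Cl)nc3ccccc23)cc1` differs from compound 2 by acetyl in place of cyano on an aromatic carbon. Within the data shown here, no measured step touches the cyano group itself, so the only guidance comes from compound 1 and compound 2, neither of which shows strong toxicity in this assay. The expected step from compound 2 to compound 3 is therefore none beyond the scatter, a step that the limit leaves unreadable from compound 2 to compound 3. Compound 3 is estimated at 30000 nM, with a range from 8000 nM to 100000 nM, and a fair chance that this assay again reports only a limit.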

Compound 3, half-maximal cytotoxic concentration: 49500 nM
Compound 3: the middle estimate sits 1.7-fold (0.22 log units) below what was measured; the measured number falls inside the stated range.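

In this assay, an acetyl group where the bromo group stood, para to a large group, gives a 1.1-fold higher number from compound 1 to compound 3 (0.04 log units; within the scatter). Within the data shown here, this is the first readable comparison at this position, and it shows that the two groups cannot be told apart in this test, which compound 1 and compound 2 alone could not show. The steps that involve compound 2 cannot be read, and the value of compound 2 remains a limit: the limit of > 8000 nM in this assay, at which 1 of the 3 values shown sits.

As far as these compounds go, whether compound 2, with its cyano group, truly lies level with compound 1 and compound 3 therefore remains open, as does whether the match between bromo and acetyl extends to other groups at this position. From the compounds shown here alone, how an amine, a carboxylic acid or a longer chain would read there in this assay also remains open, and the rest of the shared core stays the same in all three compounds, so what it contributes to these values is still unknown.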